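The source may report more compounds than this note shows. Statements on the series, on what has been measured and on what is new or still open speak of the compounds shown alone.

Compound 3 `CN(C)CC(C)(C)CNC(=O)[C@@H]1CCCN1c1nccc(Nc2ccccc2)n1` gives 0% in an assay on isolated protein for inhibition of serine/threonine-protein kinase Chk2 (Homo sapiens), read by HTRF, tested at 10 uM (a lower number here means less inhibition, a higher number more inhibition at the concentration tested (going by the name of the read-out)), the smallest of the three numbers seen, though the other two lie within the scatter of it. Compound 1 `O=C(CN1CCN(c2ncnc3c2CN(Cc2ccccc2)CC3)CC1)Nc1cc(F)ccc1F` gives 5% and compound 2 `CN(CCCn1ccnc1)C(=O)[C@@H]1CCCN1c1nccc(Nc2ccccc2)n1` gives 5% in this assay, so none of the three can be called weaker or stronger than another. Compound 4 `COC[C@@H]1CCCN1C(=O)[C@@H]1CCCN1c1nccc(Nc2ccccc2)n1` carries 2-(methoxymethyl)pyrrolidin-1-yl in place of (2-((dimethylamino)methyl)-2-methylpropyl)amino on a carbonyl carbon. Among the compounds with values here, one measured step bears on this change, because it swaps the group on the same carbonyl carbon: a number 5 percentage points lower from compound 2 to compound 3 (within the scatter). That step stayed within the scatter, so the change to compound 4 is expected to bring a number 3 percentage points higher from compound 3 to compound 4 (within the scatter), with no movement beyond the scatter. Compound 4 is estimated at 3%, within a range from -8% to 14%.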

Compound 4, a percentage reported as inhibition, at one concentration (the size of the read-out at that concentration, not a potency): 3%
Compound 4: middle estimate and measured number agree at the digits printed, and the stated range covers the measured number.
By their numbers in this assay, from the lowest: compounds 3, 4, 1 and 2 (each within the scatter of the next).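

Putting 2-(methoxymethyl)pyrrolidin-1-yl on the carbonyl carbon gives a number 3 percentage points higher from compound 3 to compound 4 (within the scatter) and a number 2 percentage points lower from compound 2 to compound 4 (within the scatter) in this assay. Three different groups at this place, now including one with no hydrogen-bond donor, therefore give numbers that cannot be told apart. Nothing available offers an explanation for this flat result. Still open, on these data alone, is whether a shorter group such as a plain methylamine, or a carboxylic acid at the end of a chain, would move the number beyond the scatter. The compounds shown also leave open whether a fluorine on the phenyl ring of the shared core would do so.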